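A few compounds are considered here, and "the series" means these few. Any claim that something is new, unique, unknown or untested is made for them only; others in the source may bear on it.

In an ADME assay on HEK-293T cells (Homo sapiens) for inhibition, read by CCK-8 assay, with a stated time of 48 h, tested at 20 uM (a higher number here means more inhibition of growth at the concentration tested, a lower number less inhibition of growth), compound 1 `Cc1ccc(S(=O)(=O)Oc2ccccc2/C=C(\C#N)C(=O)Nc2nnc(Cc3ccc(F)cc3)s2)cc1` gives 16%, and compound 2 `N#C/C(=C\c1ccccc1OS(=O)(=O)c1ccc([N+](=O)[O-])cc1)C(=O)Nc1nnc(Cc2ccc(F)cc2)s1` gives 8%. For the measured compounds named here, these two values lie within the scatter of each other, so compound 2 cannot be told apart from the only other compound measured so far. Compound 3 `N#C/C(=C\c1ccccc1OS(=O)(=O)c1ccccc1[N+](=O)[O-])C(=O)Nc1nnc(Cc2ccc(F)cc2)s1` comes from compound 2 by a single exchange, 2-nitrophenyl in place of 4-nitrophenyl on a sulfonyl sulfur. Going by the values given here, no measured pair tests this exchange directly. The nearest evidence is one step, a number 8 percentage points lower from compound 1 to compound 2 (within the scatter), in which nitro takes the place of methyl on an aromatic carbon. That single step is thin support, but it gives no sign of a large response in this assay to a change in this part of the structure. No shift beyond the scatter is therefore expected in either direction, and the expected change is a number 2 percentage points higher from compound 2 to compound 3 (within the scatter). For compound 3 the estimated value is 10%, with an expected range from 0% to 22%.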

Compound 3, percent growth inhibition at one concentration: 6%
Estimate against measurement, compound 3: 4 percentage points above; measured number inside the range.
By their numbers in this assay, from the lowest: compounds 3, 2 and 1 (each within the scatter of the next).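

In this assay, 2-nitrophenyl in place of 4-nitrophenyl on a sulfonyl sulfur gives a number 2 percentage points lower from compound 2 to compound 3 (within the scatter) and so offers the first direct test of where the nitro group sits on this aromatic ring, with no response that can be told from the scatter. Setting 2-nitrophenyl in place of 4-methylphenyl at the same sulfur gives a number 10 percentage points lower from compound 1 to compound 3 (within the scatter) and shows that this exchange, too, stays within the scatter, so the three sulfonyl substituents shown cannot be told apart in this read-out of growth inhibition. No measurement is available that would account for these readings.

The compounds shown leave open whether a different substituent on this aromatic ring, such as an amine or a carboxylic acid, or a longer alkyl chain in place of the whole ring on the sulfonyl sulfur, would give a step beyond the scatter. They also leave open whether changes elsewhere on the shared core, such as chlorine in place of the fluorine, would show the same lack of separation.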